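Swapping the sulfonamide arm for a plain butyl chain

This account rests on a few compounds, and the source may have more. Where it says the series, first, only, none or still open, it means among the compounds named here.

Compound 3, `O=C1O[C@H]([C@@H](O)Cn2cc(CNS(=O)(=O)c3ccc(Cl)cc3)nn2)C(OCc2ccccc2)=C1OCc1ccccc1`, gives 7510 nM in a functional assay on HepG2 cells (Homo sapiens) for antiproliferative activity, read by MTT assay, with a stated time of 72 h (on this read-out higher numbers stand for weaker inhibition and lower numbers for stronger inhibition), and holds the lowest number among the three measured compounds. Compound 1, `COc1ccc(-c2cn(C[C@H](O)[C@H]3OC(=O)C(OCc4ccccc4)=C3OCc3ccccc3)nn2)cc1`, gives 46400 nM, and compound 2, `O=C1O[C@H]([C@@H](O)Cn2cc(C3CC3)nn2)C(OCc2ccccc2)=C1OCc1ccccc1`, gives 38100 nM. Compound 4 is `CCCCc1cn(C[C@H](O)[C@H]2OC(=O)C(OCc3ccccc3)=C2OCc2ccccc2)nn1`; the change propyl in place of ((4-chlorophenyl)sulfonyl)amino on a saturated chain carbon bound to an aromatic carbon removes the group that marked compound 3 apart. For the measured compounds named here, the steps that bear on this are a 6.2-fold lower number from compound 1 to compound 3 (0.79 log units; beyond the scatter) and a 5.1-fold lower number from compound 2 to compound 3 (0.71 log units; beyond the scatter), both gains that arrived with the sulfonamide-bearing arm. Taking it away and leaving a butyl chain, an alkyl group like the cyclopropyl of compound 2, is expected to undo most of that gain, so a step of a 4.7-fold higher number from compound 3 to compound 4 (0.67 log units; beyond the scatter) to a higher number is expected. Compound 4 is therefore estimated at 35000 nM, within 12000 nM to 90000 nM.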

Compound 4, half-maximal inhibitory concentration: 32800 nM
Compound 4: the middle estimate sits 1.1-fold (0.03 log units) above what was measured; the range from low to high includes it.
By their numbers in this assay, from the lowest: compound 3; then compounds 4, 2 and 1 (each within the scatter of the next).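

In this assay the lower number of compound 3 is now tied to the ((4-chlorophenyl)sulfonyl)amino part, since replacing it with propyl undoes most of the gain (a 4.4-fold higher number from compound 3 to compound 4 (0.64 log units; beyond the scatter)). Butyl, cyclopropyl and 4-methoxyphenyl cannot be told apart on this aromatic carbon (a 1.2-fold lower number from compound 2 to compound 4 (0.07 log units; within the scatter); a 1.4-fold lower number from compound 1 to compound 4 (0.15 log units; within the scatter)), as both steps lie within the scatter. Which part of the arm matters, the sulfonyl, the amino hydrogen or the chlorophenyl ring, stays open, as does whether an amine or a carboxylic acid on the same chain would match it. Nothing measured here gives a reason for the gap.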